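A few compounds are considered here, and "the series" means these few. Any claim that something is new, unique, unknown or untested is made for them only; others in the source may bear on it.

Measured so far:
compound 1 `CNc1nc(-c2cc(OC)c(OC)c(OC)c2)c(-c2ccc(C(F)(F)F)cc2)s1` – 7290 nM
compound 2 `CCOc1ccc(-c2sc(NC)nc2-c2cc(OC)c(OC)c(OC)c2)cc1` – 24.5 nM

In a functional assay on MCF7 cells (Homo sapiens) for antiproliferative activity, read by MTT assay, with a stated time of 72 h (on this read-out lower numbers stand for stronger inhibition and higher numbers for weaker inhibition), compound 1 stands highest of the two numbers; the nearest is compound 2, reached by a 300-fold lower number from compound 1 to compound 2 (2.47 log units; beyond the scatter), ethoxy in place of trifluoromethyl on an aromatic carbon. Compound 3 `COc1cc(-c2nc(N(C)C)sc2-c2ccc(C(F)(F)F)cc2)cc(OC)c1OC` differs from compound 1 by methyl in place of hydrogen on a nitrogen on an aromatic ring. Among the compounds with values here, no measured step touches this nitrogen, so the measured pair gives no guide to methylamino becoming dimethylamino. The expectation for compound 3 is therefore no step beyond the scatter, a 1.0-fold lower number from compound 1 to compound 3 (0.02 log units; within the scatter). Compound 3 is estimated at 7000 nM, with a range of 2500 nM to 20000 nM.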

Compound 3, half-maximal inhibitory concentration: > 10000 nM
Compound 3: a limit, no number; the forecaster's own chance of this, stated with the estimate: 5%; middle value at least 1.4-fold (0.15 log units) away from the limit.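

Within the data shown here, this is the first reading at the nitrogen: methylamino to dimethylamino, with trifluoromethyl kept, gives an at least 1.3-fold higher number from compound 1 to compound 3 (0.13 log units; that floor lies within the scatter). The result for compound 3 is a limit of the assay and not a number: the limit of > 10000 nM in this assay, at which 1 of the 3 values shown sits.

On this background the change shows no gain, and its true size stays unread, the floor lying within the scatter. As far as these compounds go, whether the same methyl reads alike with the ethoxy of compound 2 remains open. Also open, from the compounds shown here alone, is how an unsubstituted amine or a longer chain such as ethyl on this nitrogen would read.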